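The source may hold more compounds than are shown below. What is called first, only, known or untested is meant among the compounds shown, and "the series" means these compounds.

In a functional assay on COLO 205 cells (Homo sapiens) for antiproliferative activity, read by sulforhodamine B assay, with a stated time of 72 h (on this read-out lower numbers stand for stronger inhibition and higher numbers for weaker inhibition), compound 1 (`O=C1CS/C(=N/Nc2nncc3ccccc23)N1c1ccccc1`) gives 32 nM, compound 2 (`O=S(=O)(Nc1ncccn1)c1ccc(Nc2nncc3ccccc23)cc1`) gives 43 nM and compound 3 (`O=C1CS/C(=N/Nc2nncc3ccccc23)N1`) gives 55 nM. Compound 2 therefore lies within the scatter of both other compounds, and the three numbers cannot be ranked.

Compound 4 (`Cc1cc(NS(=O)(=O)c2ccc(Nc3nncc4ccccc34)cc2)no1`) differs from compound 2 in one place: 5-methyl-1,2-oxazol-3-yl in place of pyrimidin-2-yl on a sulfonamide nitrogen. In words, 5-methyl-1,2-oxazol-3-yl stands in place of pyrimidin-2-yl on a sulfonamide nitrogen.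

Within the data shown here, no measured step covers this exchange. The only one available, a 1.7-fold higher number from compound 1 to compound 3 (0.24 log units; within the scatter), puts hydrogen in place of phenyl on an amide-type nitrogen in a ring, so it bears on the change only indirectly. It does show one substituent exchange in this small set that stays within the scatter.

With compound 2 at 43 nM as the anchor, no shift beyond the scatter is expected in this assay. The expected step is a 1.0-fold higher number from compound 2 to compound 4 (0.02 log units; within the scatter). Compound 4 is estimated at 45 nM, with an expected range of 15 nM to 130 nM.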

Compound 4, half-maximal inhibitory concentration: 43 nM
For compound 4 the middle estimate is 1.0-fold (0.02 log units) above the measured one; the measured number falls inside the stated range.
By their numbers in this assay, from the lowest: compounds 1, 2, 4 and 3 (each within the scatter of the next).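

In this assay, among these compounds, 5-methyl-1,2-oxazol-3-yl in place of pyrimidin-2-yl on a sulfonamide nitrogen gives no change at the digits printed from compound 2 to compound 4 (within the scatter), the first reading at this position, since the earlier step concerned an amide-type nitrogen in a ring. For this one pair, a five-membered aromatic ring with 2 hetero atoms and a six-membered aromatic ring with 2 hetero atoms, each of 6 heavy atoms and uncharged, read alike on the sulfonamide nitrogen. No supporting data bear on why the two groups read alike.

Both groups are aromatic rings, so the compounds shown leave open how this nitrogen responds to a group of another kind, such as a plain methyl or a chain ending in an amine or a carboxylic acid. Also open, from the compounds shown here alone, is whether a bare hydrogen on that nitrogen would read the same.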